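This account rests on a few compounds, and the source may have more. Where it says the series, first, only, none or still open, it means among the compounds named here.

Three compounds of a shared core were tested in a functional assay on MCF7 cells (Homo sapiens) for inhibition, read by MTT assay, with a stated time of 48 h; on this read-out lower numbers stand for stronger inhibition and higher numbers for weaker inhibition. Compound 1 `Brc1ccc(CSc2nnc(-c3ccncc3)n2-c2ccccc2)cc1` gives 12600 nM. Compound 2 `O=[N+]([O-])c1ccccc1CSc1nnc(-c2ccncc2)n1-c1ccccc1` reaches only the limit of this assay, > 50000 nM. Compound 3 `O=C(CSc1nnc(-c2ccncc2)n1-c1ccccc1)N/N=C/c1ccc(Br)cc1` gives 7040 nM, which lies within the usual scatter of the number for compound 1. The value of compound 2 is a limit, and the limit of > 50000 nM in this assay, at which 1 of the 3 values shown sits, describes where it sits.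

Compound 4 `O=C(CSc1nnc(-c2ccncc2)n1-c1ccccc1)N/N=C/c1cc(Br)ccc1O` has not yet been measured in this assay. It differs from compound 3 in one place: 5-bromo-2-hydroxyphenyl in place of 4-bromophenyl on a carbon with a double bond to nitrogen. Among the measured compounds shown here, the only measured step with one change, an at least 3.9-fold higher number from compound 1 to compound 2 (0.59 log units; beyond the scatter), concerns a different place, on a saturated chain carbon bound to a sulfur, so it bears only loosely on the present change; no measured step adds a hydroxyl to an aryl group. The expected step for this change is therefore small, a 1.0-fold lower number from compound 3 to compound 4 (0.00 log units; within the scatter), with no direction beyond the scatter clearly favoured. For compound 4 the estimate in this assay is 7000 nM, with a range from 3000 nM to 20000 nM.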

Compound 4, half-maximal inhibitory concentration: 6460 nM
Beside the measured number, compound 4's estimate is 1.1-fold (0.03 log units) above it; measured number inside the range.
By their numbers in this assay, from the lowest: compounds 4, 3 and 1 (each within the scatter of the next). At a limit, above all of these: compound 2.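

At the place on a carbon with a double bond to nitrogen, putting 5-bromo-2-hydroxyphenyl in place of 4-bromophenyl gives a 1.1-fold lower number from compound 3 to compound 4 (0.04 log units; within the scatter) in this assay. This is the first step shown at this place, and it shows that the aryl group there can carry a hydroxyl and a differently placed bromine without the number moving beyond the scatter, whereas the only earlier step, at the saturated chain carbon bound to a sulfur, did move beyond it. Nothing in the data shown accounts for this result.

The hydroxyl and the new bromine placement arrive together in one group, and the compounds shown do not separate the two. On these data alone, how an amine or a methoxy group in place of that hydroxyl, or a phenyl without bromine, would read at this place remains open.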